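A Smaller Group on the Piperidine Ring

This account rests on a few compounds, and the source may have more. Where it says the series, first, only, none or still open, it means among the compounds named here.

The two measured compounds, compound 1 `CCCCNc1nc(C(F)(F)F)ccc1CNC(=O)C(C)c1ccc(NS(C)(=O)=O)c(F)c1` and compound 2 `CC(C(=O)NCc1ccc(C(F)(F)F)nc1N1CCC(C(=O)c2ccc(F)cc2)CC1)c1ccc(NS(C)(=O)=O)c(F)c1`, were tested in a functional assay on CHO-K1 cells for antagonist activity at transient receptor potential cation channel subfamily V member 1 (Homo sapiens), read by FLIPR; a lower number here means a stronger inhibitor, a higher number a weaker inhibitor. Compound 1 gives 9.1 nM, and compound 2 gives 3.9 nM, the lowest of the two numbers; the gap to compound 1 lies beyond the usual scatter of repeated measurements.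

Compound 3 `CC(C(=O)NCc1ccc(C(F)(F)F)nc1N1CCC(C(F)(F)F)CC1)c1ccc(NS(C)(=O)=O)c(F)c1` is not yet measured. It differs from compound 2 in one place: trifluoromethyl in place of (4-fluorophenyl)carbonyl on a saturated ring carbon. For the measured compounds named here, a large aromatic group is thus exchanged for a small one on the shared core, and no measured pair shows what such an exchange does.

Some loss of potency is expected from this change, but a moderate one, because compound 1, which carries a different group on the shared core, still gives 9.1 nM. Compound 3 is therefore estimated at 9 nM, within a range from 3 nM to 27 nM. The expected step is a 2.3-fold higher number from compound 2 to compound 3 (0.36 log units; beyond the scatter).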

Compound 3, inhibition constant: 0.6 nM
Beside the measured number, compound 3's estimate is 15-fold (1.18 log units) above it, outside the stated range (below it).
By their numbers in this assay, from the lowest: compound 3; then compound 2; then compound 1.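

On the saturated ring carbon, the large (4-fluorophenyl)carbonyl group is not required for strong inhibition in this assay: replacing it with the smaller trifluoromethyl gives a 6.5-fold lower number from compound 2 to compound 3 (0.81 log units; beyond the scatter) and thus a gain rather than a loss. The second comparison, 4-(trifluoromethyl)piperidin-1-yl in place of butylamino on an aromatic carbon, gives a 15-fold lower number from compound 1 to compound 3 (1.18 log units; beyond the scatter) and shows that this ring with its small group also outperforms the open butyl chain. Nothing measured here explains why either change lowers the number.

Trifluoromethyl is the only small group shown at this ring carbon, so it remains open whether a methyl, a nitrile or a hydroxyl there would give a similar number. It is also unclear whether a pentafluoroethyl group, slightly larger than trifluoromethyl, would lower the number further or raise it.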